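Moving the fluorine on the anilide of compound 1

The source may report more compounds than this note shows. Statements on the series, on what has been measured and on what is new or still open speak of the compounds shown alone.

compound 1 `CN(C)C(=O)c1cc2cnc(Nc3ccc(NC(=O)C4(C(=O)Nc5ccc(F)cc5)CC4)cc3)nc2n1C1CCCC1`: 98%
compound 2 `CN(C)C(=O)c1cc2cnc(Nc3ccc(N)cn3)nc2n1C1CCCC1`: 61.5%

In a functional assay on SiHa cells (Homo sapiens) for inhibition, read by CCK-8 assay, with a stated time of 72 h, tested at 10 uM (on this read-out lower numbers stand for less inhibition of growth and higher numbers for more inhibition of growth at the one concentration tested), compound 1 gives 98%, the higher of the two values, and compound 2 gives 61.5%, a gap beyond the scatter. Compound 3 `CN(C)C(=O)c1cc2cnc(Nc3ccc(NC(=O)C4(C(=O)Nc5cccc(F)c5)CC4)cc3)nc2n1C1CCCC1` has 3-fluorophenyl in place of 4-fluorophenyl on an amide-type nitrogen. For the measured compounds named here, no measured pair shows this change. The expected step of a number 5 percentage points lower from compound 1 to compound 3 (within the scatter) is small and slightly downward, within the scatter. Compound 3 is estimated at 93%, with an expected range of 80% to 100%.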

Compound 3, percent growth inhibition at one concentration: 107%
Compound 3: middle estimate off by 14 percentage points, on the low side; the whole stated range lies below it.
By their numbers in this assay, from the lowest: compound 2; then compounds 1 and 3 (each within the scatter of the next).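

In this assay, 3-fluorophenyl in place of 4-fluorophenyl on an amide-type nitrogen gives a number 9 percentage points higher from compound 1 to compound 3 (within the scatter), so at the one concentration tested this read-out does not tell the two fluorophenyl groups apart. For the compounds shown here, this is the first step at this position, and it holds the rest of compound 1 fixed. No measurement at hand accounts for this result.

The compounds shown leave open how an unsubstituted phenyl, a 3-chlorophenyl or a pyridyl group would read on this nitrogen. They also leave open whether compound 1 and compound 3 would separate at lower concentrations.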